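Hydroxy for Chloro, Repeated on a Second Core

The source may hold more compounds than are shown below. What is called first, only, known or untested is meant among the compounds shown, and "the series" means these compounds.

The set holds two pairs. Compound 1 `Cn1c(SCC(=O)Nn2c(COc3ccc(Cl)cc3Cl)nc3ccccc3c2=O)nc(-c2ccc(Cl)cc2)c(C#N)c1=O` and compound 2 `Cn1c(SCC(=O)Nn2c(COc3ccc(Cl)cc3Cl)nc3ccccc3c2=O)nc(-c2ccc(O)cc2)c(C#N)c1=O` share one core, while compound 3 `N#Cc1c(Nc2ccc(Cl)cc2)nc(SCC(=O)Nn2c(COc3ccc(Cl)cc3Cl)nc3ccccc3c2=O)nc1-c1ccccc1` and compound 4 `N#Cc1c(Nc2ccc(O)cc2)nc(SCC(=O)Nn2c(COc3ccc(Cl)cc3Cl)nc3ccccc3c2=O)nc1-c1ccccc1` share another; how the two cores differ is not broken down here.

In a functional assay on the whole organism (strain albino) for inhibition, with Rattus norvegicus as the target, read by paw edema, with a stated time of 1 h, at a dose of 100 mg/kg by the oral route (on this read-out higher numbers stand for more inhibition at the one dose given (going by the name of the read-out) and lower numbers for less inhibition), compound 1 gives 76.4%. In this assay compound 2 gives 80%. The change between them is hydroxy in place of chloro on an aromatic carbon, and it produced a number 3.6 percentage points higher from compound 1 to compound 2 (within the scatter). In this assay compound 3 gives 54.6%, the lowest of the three measured numbers, standing beyond the scatter below both compound 1 and compound 2.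

Compound 4 is not yet measured. It differs from compound 3 by hydroxy in place of chloro on an aromatic carbon. The place is the same as in the earlier pair, a six-membered aromatic ring of carbon only, para to a large group, though in compound 3 that ring is carried through an amino link, so the change reads as (4-chlorophenyl)amino to (4-hydroxyphenyl)amino rather than the bare 4-chlorophenyl to 4-hydroxyphenyl seen between compound 1 and compound 2.

For compound 4 the expected step in this assay is a number 3.4 percentage points higher from compound 3 to compound 4 (within the scatter), which rests on the earlier step from compound 1 to compound 2 being a number 3.6 percentage points higher from compound 1 to compound 2 (within the scatter), a step within the scatter. On that basis compound 4 is estimated at 58% in this assay, expected to fall between 45% and 71%.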

Compound 4, a percentage reported as inhibition, in the whole organism at one dose (the size of the read-out at that dose, not a potency): 72.7%
Estimate against measurement, compound 4: 14.7 percentage points below; measured number above the stated range.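

In this assay, hydroxy in place of chloro gave a number 18.1 percentage points higher from compound 3 to compound 4 (beyond the scatter), so on the core of compound 3 the change produced a step that stands clear of the scatter. Carried from one core to the other, the same change therefore did not keep its size: the same change on two cores in this assay, a number 3.6 percentage points higher (within the scatter) from compound 1 to compound 2 and a number 18.1 percentage points higher (beyond the scatter) from compound 3 to compound 4, 14.5 percentage points apart, beyond the scatter of two such steps

This does not show which difference between the two cores goes with the gap. The amino link that carries the ring in compound 3 and compound 4 is one such difference, but these two pairs cannot separate it from the others, and two pairs read at a single dose and a single time give no rule for predicting the step on a third core.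

The compounds shown leave open what other groups would do at the same place on that ring, for example a methoxy group, an amine or a carboxylic acid in place of the hydroxy. They also leave open whether the size of the step on either core would hold at another dose or at another time after dosing.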